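Amide swap on the benzylbenzimidazole piperazine series

This account rests on a few compounds, and the source may have more. Where it says the series, first, only, none or still open, it means among the compounds named here.

Compound 1 `Cc1cccc(Cn2c(CN3CCN(C(=O)c4ccc(C(C)C)cc4)CC3)nc3ccccc32)c1` is measured in an assay on isolated protein for inhibition of aldehyde dehydrogenase 1A1 (Homo sapiens), read by spectrophotometry, tested at 10 uM (on this read-out lower numbers stand for less inhibition and higher numbers for more inhibition at the one concentration tested (going by the name of the read-out)), and gives 67.6%, the second highest of the three numbers in hand; its nearest neighbour is compound 3 `CC(C)CCn1c(CN2CCN(C(=O)C3CC3)CC2)nc2ccccc21`, which in this assay gives 70%, a gap within the scatter, while compound 2 `Cc1ccccc1Cn1c(CN2CCN(C(=O)C3CC3)CC2)nc2ccccc21` gives 29.1%, well below it. Going by the values given here, the one step recorded, a number 40.9 percentage points higher from compound 2 to compound 3 (beyond the scatter), concerns the substituent on the aromatic nitrogen, not the amide. Compound 4 `Cc1cccc(Cn2c(CN3CCN(C(=O)C(C)C)CC3)nc3ccccc32)c1` differs from compound 1 only at the carbonyl: isopropyl in place of 4-isopropylphenyl on a carbonyl carbon. Among the compounds with values here, no measured pair isolates this change; the only small-alkyl amides in hand are compound 2 and compound 3, which sit on either side of compound 1 and carry a different nitrogen substituent. Compound 2 suggests a small amide with a methylbenzyl group can sit low, so a fall from compound 1 is expected, estimated at a number 17.6 percentage points lower from compound 1 to compound 4 (beyond the scatter), with wide uncertainty. Compound 4 is therefore expected to give about 50% in this assay, within a range of 25% to 75%.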

Compound 4, a percentage reported as inhibition, at one concentration (the size of the read-out at that concentration, not a potency): 87.2%
Estimate against measurement, compound 4: 37.2 percentage points below; measured number above the stated range.
By their numbers in this assay, from the lowest: compound 2; then compounds 1 and 3 (each within the scatter of the next); then compound 4.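

In this assay, isopropyl in place of 4-isopropylphenyl on a carbonyl carbon gives a number 19.6 percentage points higher from compound 1 to compound 4 (beyond the scatter), so the six-membered aromatic ring at this position is not required for inhibition at the one concentration tested. Going by these compounds alone, this is the first step read at the amide itself, as the earlier step concerned the substituent on the aromatic nitrogen, and it shows that this position responds to the change even with the rest of compound 1 held fixed. Nothing in hand explains the rise.

From the compounds shown here alone, whether a longer chain, an amine or a carboxylic acid on this carbonyl carbon would keep the inhibition remains open. So does whether the step carries over to other substituents on the aromatic nitrogen, and how it would read at concentrations other than the one tested.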